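The compounds below may be only part of what the source reports. "The series", "measured", "known", "first", "only" and "open" are said of these compounds alone.

Values measured so far in an in vitro ADME assay on microsomes from liver (Homo sapiens) for metabolic stability (a lower number here means slower removal, a higher number faster removal of the compound), are these:

- compound 1 `CC(C)NC(=O)[C@H]1CC[C@@H](n2/c(=N/C(=O)c3ccc(C#N)c(F)c3)[nH]c3ccc(CN4CCC(C(C)(C)O)CC4)cc32)CC1` gives 132 mL.min-1.g-1
- compound 2 `COC(=O)[C@H]1CC[C@@H](n2/c(=N/C(=O)c3ccccc3)[nH]c3ccc(CN4CCCCC4)cc32)CC1` gives 85 mL.min-1.g-1
- compound 3 `CC(C)NC(=O)[C@H]1CC[C@@H](n2/c(=N/C(=O)c3ccc(F)cc3)[nH]c3ccc(CN4CCC[C@H]4C(C)(C)O)cc32)CC1` gives 569 mL.min-1.g-1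

Compound 2 and compound 1 lie within the usual scatter of each other. Compound 3 carries the higher number when set against compound 2, and that gap lies beyond the scatter.

The next compound to consider is compound 4 `CC(C)NC(=O)[C@H]1CC[C@@H](n2/c(=N/C(=O)c3ccccc3)[nH]c3ccc(CN4CCCCC4)cc32)CC1`, which differs from compound 2 in one place. The change is isopropylamino in place of methoxy on a carbonyl carbon and the rest of the structure stays the same. Isopropylamino stands in place of methoxy on a carbonyl carbon, so methoxycarbonyl becomes isopropylcarbamoyl.

Going by the values given here, no two measured compounds show this change alone, so its size cannot be read directly. Compound 1 and compound 3 both carry isopropylcarbamoyl, but each also differs from compound 4 elsewhere. A modest rise is expected, guided by compound 1 with 132 mL.min-1.g-1 as the closer reference, while compound 3 with 569 mL.min-1.g-1 keeps the upper end of the expectation wide. The estimated change is a 1.5-fold higher number from compound 2 to compound 4 (0.18 log units; within the scatter) and is expected to stay within the scatter. For compound 4 the expected value is 130 mL.min-1.g-1 with an estimated range from 60 mL.min-1.g-1 to 320 mL.min-1.g-1 in this assay once measured.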

Compound 4, intrinsic clearance in microsomes: 203 mL.min-1.g-1
The estimate for compound 4 lay 1.6-fold (0.19 log units) below the measured number; the measured number falls inside the stated range.
By their numbers in this assay, from the lowest: compounds 2, 1 and 4 (each within the scatter of the next, the first and the last beyond it); then compound 3.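

In this assay, isopropylamino in place of methoxy on a carbonyl carbon, with a saturated ring carbon as its other neighbour, gives a 2.4-fold higher number from compound 2 to compound 4 (0.38 log units; beyond the scatter). This is the first pair shown that differs in one place only, so it reveals that turning methoxycarbonyl into isopropylcarbamoyl alone moves the number beyond the usual scatter, towards faster removal, without help from changes elsewhere in the structure. No measurement here accounts for this rise, so the data show its size but not its cause.

A single step cannot separate the part played by the nitrogen and its hydrogen from the part played by the isopropyl chain, and methylamino, dimethylamino or a carboxylic acid on the same carbonyl carbon would be needed to tell these apart. On these data alone, it also remains open whether the same swap gives a step of similar size when the rest of the molecule carries the other groups seen in compound 1 or compound 3, such as the nitrile or the fluorine.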